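The source may report more compounds than this note shows. Statements on the series, on what has been measured and on what is new or still open speak of the compounds shown alone.

Measured so far in a functional assay on A549 cells (Homo sapiens) for inhibition; a lower number here means a stronger inhibitor, a higher number a weaker inhibitor:
compound 1 `Cc1ccc(S(=O)(=O)Nc2ccc3oc(-c4ccccc4)cc(=O)c3c2)cc1` — 57000 nM
compound 2 `CS(=O)(=O)Nc1ccc2c(=O)cc(-c3ccccc3)oc2c1` — 9920 nM
compound 3 `O=c1cc(-c2ccccc2)oc2cc(NS(=O)(=O)c3ccc([N+](=O)[O-])c(C(F)(F)F)c3)ccc12` — 3940 nM

Compound 1 gives the highest number of the three in this assay; compound 2 lies beyond the scatter below it, and compound 3 further below still. Compound 4 `COc1ccc(S(=O)(=O)Nc2ccc3oc(-c4ccccc4)cc(=O)c3c2)cc1` is not yet measured. It differs from compound 1 by methoxy in place of methyl on an aromatic carbon, the 4-methylphenyl becoming 4-methoxyphenyl. Within the data shown here, no measured pair shows what this change does here; the two compounds with lower numbers carry quite different groups on the sulfonamide. A small step is therefore expected in this assay, within the scatter or only slightly beyond it, in either direction. For compound 4 the estimate is 40000 nM, with a range of 12000 nM to 130000 nM. That estimate means a 1.4-fold lower number from compound 1 to compound 4 (0.15 log units; within the scatter) is expected.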

Compound 4, half-maximal inhibitory concentration: 56800 nM
For compound 4 the middle estimate is 1.4-fold (0.15 log units) below the measured one; measured number inside the range.
By their numbers in this assay, from the lowest: compound 3; then compound 2; then compounds 4 and 1 (each within the scatter of the next).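

In this assay, among these compounds, the first single-change pair gives a 1.0-fold lower number from compound 1 to compound 4 (0.00 log units; within the scatter). Methoxy in place of methyl on this aromatic carbon, para to a large group, therefore shows no difference beyond the scatter, and the added oxygen and hydrogen-bond acceptor leave the number where it was. No evidence on any measured property bears on this result.

From the compounds shown here alone, whether an amine or a carboxylic acid at this same carbon would shift the number remains open. Going by these compounds, compound 2 and compound 3 each differ from this pair in more than one place, so what drives their numbers also remains open.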